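Nitro on compound 3: expected step

A few compounds are considered here, and "the series" means these few. Any claim that something is new, unique, unknown or untested is made for them only; others in the source may bear on it.

In a functional assay on NAMALVA cells (Homo sapiens) for cytotoxicity, read by MTT assay, with a stated time of 72 h (on this read-out lower numbers stand for stronger inhibition and higher numbers for weaker inhibition), compound 1 `O=C(Nc1ccccc1)Nc1ccc(C(=O)NO)cc1` gives 530 nM, compound 2 `COc1ccc(NC(=O)Nc2ccc(C(=O)NO)cc2)cc1` gives 4790 nM and compound 3 `O=C(/C=C/c1ccc(NC(=O)Nc2ccccc2)cc1)NO` gives 300 nM. Compound 3 shares the low end of these numbers with compound 1, as shown by a 1.8-fold lower number from compound 1 to compound 3 (0.25 log units; within the scatter). Compound 2 stands well apart from both.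

Compound 4 `O=C(/C=C/c1ccc(NC(=O)Nc2ccc([N+](=O)[O-])cc2)cc1)NO` differs from compound 3 by one change: nitro in place of hydrogen on an aromatic carbon, para to a large group. The closest measured step is the methoxy exchange, a 9.0-fold higher number from compound 1 to compound 2 (0.96 log units; beyond the scatter), a modest move to a higher number. The step between compound 1 and compound 3 stays within the scatter, which gives no sign that the methoxy step would fail to carry over. Going by the values given here, no nitro compound has been measured, however, and the methoxy step is a single pair with a different group, so a smaller rise is expected in this assay. The expected shift is a 3.0-fold higher number from compound 3 to compound 4 (0.48 log units; beyond the scatter). For compound 4 the estimated value is 900 nM, with an expected range from 200 nM to 4000 nM.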

Compound 4, half-maximal inhibitory concentration: 580 nM
Beside the measured number, compound 4's estimate is 1.6-fold (0.19 log units) above it; the measured number falls inside the stated range.
By their numbers in this assay, from the lowest: compounds 3, 1 and 4 (each within the scatter of the next); then compound 2.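

In this assay the nitro exchange gives a 1.9-fold higher number from compound 3 to compound 4 (0.29 log units; within the scatter) so at this place, para to a large group, hydrogen and nitro cannot be told apart on this read-out. A substituent here therefore does not always bring a step beyond the scatter, as the methoxy exchange did with a 9.0-fold higher number from compound 1 to compound 2 (0.96 log units; beyond the scatter) on a different parent, and the two groups have not been compared on the same parent. The data offer no explanation for the contrast between these two steps.

From the compounds shown here alone, whether an amine or a carboxylic acid at this place would also stay within the scatter of compound 3 remains open. Also open, going by these compounds, is whether nitro would give a similar step on compound 1, and methoxy a similar step on compound 3.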